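The compounds below may be only part of what the source reports. "The series", "measured", "known", "first", "only" and "open" are said of these compounds alone.

In a functional assay on MDA-MB-231 cells (Homo sapiens) for antiproliferative activity, read by MTT assay, with a stated time of 48 h (a higher number here means a weaker inhibitor of growth, a lower number a stronger inhibitor of growth), the measured compounds are:
Compound 1 `COC(=O)N1N=C(c2ccccc2)CC1c1cc(OC)c(OC)c(OC)c1`: 1080 nM
Compound 2 `COC(=O)N1N=C(c2ccc(OC)cc2)CC1c1cc(OC)c(OC)c(OC)c1`: 1990 nM
Compound 3 `COC(=O)N1N=C(c2cccc(C)c2)CC1c1cc(OC)c(OC)c(OC)c1`: 140 nM

Compound 3, at 140 nM, gives the lowest of the three numbers. Compound 4 `COC(=O)N1N=C(c2ccc(O)cc2)CC1c1cc(OC)c(OC)c(OC)c1` replaces its 3-methylphenyl with 4-hydroxyphenyl on a carbon with a double bond to nitrogen: 4-hydroxyphenyl in place of 3-methylphenyl on a carbon with a double bond to nitrogen. For the measured compounds named here, no measured compound carries 4-hydroxyphenyl. The nearest evidence is compound 2, with 4-methoxyphenyl at that place, and a 14-fold lower number from compound 2 to compound 3 (1.15 log units; beyond the scatter) is large. The modest 7.7-fold lower number from compound 1 to compound 3 (0.89 log units; beyond the scatter) shows what the methyl accompanied, while a 1.8-fold higher number from compound 1 to compound 2 (0.27 log units; within the scatter) stays within the scatter. In this assay, a large rise is therefore expected, an estimated 11-fold higher number from compound 3 to compound 4 (1.03 log units; beyond the scatter). Compound 4 is expected at about 1500 nM, within an estimated range of 500 nM to 4500 nM.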

Compound 4, concentration for 50% growth inhibition: 7150 nM
Beside the measured number, compound 4's estimate is 4.8-fold (0.68 log units) below it; measured number above the stated range.
By their numbers in this assay, from the lowest: compound 3; then compounds 1 and 2 (each within the scatter of the next); then compound 4.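

In this assay, methoxy on the aromatic ring stayed within the scatter of hydrogen, but hydroxy does not: a 6.6-fold higher number from compound 1 to compound 4 (0.82 log units; beyond the scatter) separates these two compounds. The hydrogen on that oxygen therefore matters, with a 3.6-fold higher number from compound 2 to compound 4 (0.56 log units; beyond the scatter) following from the loss of the methyl alone. Set against the 3-methylphenyl, the 4-hydroxyphenyl gives a 51-fold higher number from compound 3 to compound 4 (1.71 log units; beyond the scatter) at this place, the widest gap among the four compounds. From the compounds shown here alone, whether a 4-aminophenyl or a 3-hydroxyphenyl would follow compound 4 or compound 3 stays open. Nothing measured here explains these steps.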